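The source may report more compounds than this note shows. Statements on the series, on what has been measured and on what is new or still open speak of the compounds shown alone.

Compound 3 `CN(C)CCn1cnnc1-c1cc(Oc2ccc(NC(=O)N/N=C/c3c(O)ccc4ccccc34)cc2F)ccn1` has been measured in a functional assay on A549 cells (Homo sapiens) for cytotoxicity, read by MTT assay, with a stated time of 72 h; on this read-out lower numbers stand for stronger inhibition and higher numbers for weaker inhibition. In this assay compound 3 gives 880 nM, the lowest of the two numbers shown. Its nearest neighbour is compound 1 `CN(C)CCn1cnnc1-c1cc(Oc2ccc(NC(=O)N/N=C/c3ccc(O)c(Br)c3)cc2F)ccn1`, which in this assay gives 1370 nM; the two sit within the scatter of each other, as a 1.6-fold lower number from compound 1 to compound 3 (0.19 log units; within the scatter) shows. Compound 2 `COc1cc(/C=N/NC(=O)Nc2ccc(Oc3ccnc(-c4nncn4CCN(C)C)c3)c(F)c2)cc(OC)c1OC` gives only a limit of this assay, > 100000 nM, which is the limit of > 100000 nM in this assay, at which 1 of the 3 values shown sits. Two large steps touch the same place on the core as the change below: an at least 72-fold higher number from compound 1 to compound 2 (1.86 log units; beyond the scatter) and an at least 110-fold lower number from compound 2 to compound 3 (2.05 log units; beyond the scatter).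

Compound 4 `CN(C)CCn1cnnc1-c1cc(Oc2ccc(NC(=O)N/N=C/c3ccc(O)cc3)cc2F)ccn1` has not yet been measured. It differs from compound 3 in one place: 4-hydroxyphenyl in place of 2-hydroxynaphthalen-1-yl on a carbon with a double bond to nitrogen. The group that enters carries a hydroxyl, as do the groups of compound 3 and of compound 1, whereas both large steps involved the trimethoxyphenyl group of compound 2. The small step between compound 1 and compound 3 is the closer guide. The expected step is therefore small and within the scatter, leaning towards a slightly higher number: a 2.0-fold higher number from compound 3 to compound 4 (0.31 log units; beyond the scatter). Compound 4 is expected to give about 1800 nM in this assay, with a range from 700 nM to 5000 nM.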

Compound 4, half-maximal inhibitory concentration: 3560 nM
Beside the measured number, compound 4's estimate is 2.0-fold (0.30 log units) below it, and the stated range covers the measured number.
By their numbers in this assay, from the lowest: compounds 3 and 1 (each within the scatter of the next); then compound 4. At a limit, above all of these: compound 2.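

The change from two six-membered aromatic rings in 2-hydroxynaphthalen-1-yl to one in 4-hydroxyphenyl matters at this position: in this assay there is a 4.0-fold higher number from compound 3 to compound 4 (0.61 log units; beyond the scatter), so carrying a hydroxyl does not alone keep the number at the level of compound 3. Among the compounds shown here, compound 4 also gives the first reading of the bromo on its own, as hydrogen in place of bromo on an aromatic carbon gives a 2.6-fold higher number from compound 1 to compound 4 (0.41 log units; beyond the scatter), a modest step beyond the scatter. The large gap to the trimethoxyphenyl group remains, at an at least 28-fold lower number from compound 2 to compound 4 (1.44 log units; beyond the scatter), a step that starts from a limit of the assay rather than a number, so the three hydroxyl-bearing groups shown all stay well clear of compound 2.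

The data shown give no measured property that explains any of these steps. On these data alone, whether the hydroxyl itself is needed remains open, and a plain phenyl, or a phenyl with a single methoxy or an amine in place of the hydroxyl, would test this.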